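The source may report more compounds than this note shows. Statements on the series, on what has been measured and on what is new or still open speak of the compounds shown alone.

Measured so far in an assay on brain for binding affinity to adenosine receptor A1 (Rattus norvegicus), read by radioligand binding; a higher number here means a weaker inhibitor, a lower number a stronger inhibitor: compound 1 `CCCn1c(=O)c2nc(-c3ccc(OCC(=O)NCCN=C(S)Nc4ccc(C)cc4)cc3)[nH]c2n(CCC)c1=O` with 16 nM; compound 2 `CCCn1c(=O)c2nc(-c3ccc(OCC(=O)NCCN=C(S)Nc4ccc(OC)cc4)cc3)[nH]c2n(CCC)c1=O` with 33.2 nM; compound 3 `CCCn1c(=O)c2nc(-c3ccc(OCC(=O)NCCNC(=O)CCCCC(C)=O)cc3)[nH]c2n(CCC)c1=O` with 44 nM.

Compound 3 gives the highest number of the three: one step is a 1.3-fold higher number from compound 2 to compound 3 (0.12 log units; within the scatter), the other is a 2.8-fold higher number from compound 1 to compound 3 (0.44 log units; beyond the scatter).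

Compound 4 `CCCn1c(=O)c2nc(-c3ccc(OCC(=O)NCCNC(=O)CCCN4C(=O)C=CC4=O)cc3)[nH]c2n(CCC)c1=O` differs from compound 3 by a group of 7 heavy atoms (4 carbon, 1 nitrogen, 2 oxygen; one five-membered non-aromatic ring with 1 hetero atom) in place of a group of 4 heavy atoms (3 carbon, 1 oxygen; no ring), on a saturated chain carbon, three bonds along the chain from a carbonyl carbon. Within the data shown here, no measured step touches exactly this place. The nearest precedents, a 2.8-fold higher number from compound 1 to compound 3 (0.44 log units; beyond the scatter) and a 1.3-fold higher number from compound 2 to compound 3 (0.12 log units; within the scatter), each swapped a much larger group for the present chain and moved the number only modestly. Compound 4 is therefore expected to stay near compound 3, with a 1.1-fold higher number from compound 3 to compound 4 (0.06 log units; within the scatter) within the scatter. The estimate for compound 4 is 50 nM, ranging from 20 nM to 125 nM.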

Compound 4, inhibition constant: 37.8 nM
The estimate for compound 4 lay 1.3-fold (0.12 log units) above the measured number, and the stated range covers the measured number.
By their numbers in this assay, from the lowest: compound 1; then compounds 2, 4 and 3 (each within the scatter of the next).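

Exchanging 2-oxopropyl for the group with one five-membered non-aromatic ring, on a saturated chain carbon three bonds along the chain from a carbonyl carbon, gives a 1.2-fold lower number from compound 3 to compound 4 (0.07 log units; within the scatter) in this assay. Among these compounds, at this place, then, the ring and the larger group of 7 heavy atoms leave the number within the scatter, a change the earlier compounds did not test. No evidence is available to account for this result.

Going by these compounds, whether the same holds for an amine, a carboxylic acid or a longer chain at this place remains open. Among the compounds shown here, compound 1 stays the only compound with a step beyond the scatter from compound 3, and its aromatic ring lies in a much larger group.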